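The source may hold more compounds than are shown below. What is called first, only, known or untested is meant among the compounds shown, and "the series" means these compounds.

Measured so far in a functional assay on HeLa cells (Homo sapiens) for cytotoxicity, read by MTT assay; on this read-out lower numbers stand for stronger inhibition and higher numbers for weaker inhibition:
compound 1 `CC(=O)OCCO[C@H](CC=C(C)C)C1=CC(=O)c2c(O)ccc(O)c2C1=O`, 41500 nM
compound 2 `CC(C)=CC[C@@H](OC(=O)C1CCOC1)C1=CC(=O)c2c(O)ccc(O)c2C1=O`, 73500 nM
compound 3 `CC(=O)OC(C)CO[C@H](CC=C(C)C)C1=CC(=O)c2c(O)ccc(O)c2C1=O`, 40100 nM

All three numbers lie within the usual scatter of one another. Going by the values given here, compound 1 sits closest to compound 3 and furthest from compound 2, but no pair is separated beyond the scatter. The steps confirm this: a 1.8-fold higher number from compound 1 to compound 2 (0.25 log units; within the scatter), a 1.0-fold lower number from compound 1 to compound 3 (0.01 log units; within the scatter) and a 1.8-fold lower number from compound 2 to compound 3 (0.26 log units; within the scatter).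

Compound 4 `CCC(C)(O)CC(=O)O[C@H](CC=C(C)C)C1=CC(=O)c2c(O)ccc(O)c2C1=O` is to be measured. Its difference from compound 1: (2-hydroxy-2-methylbutyl)carbonyl in place of 2-acetoxyethyl on an oxygen on a saturated carbon. Among the compounds with values here, the nearest precedent is the step where (oxolan-3-yl)carbonyl took the place of 2-acetoxyethyl on an oxygen on a saturated carbon, which gave a 1.8-fold higher number from compound 1 to compound 2 (0.25 log units; within the scatter). The step where methyl took the place of hydrogen in the side chain gave a 1.0-fold lower number from compound 1 to compound 3 (0.01 log units; within the scatter). Both were within the scatter; changes on this oxygen have so far not moved the numbers. On that basis no step beyond the scatter is expected in this assay for compound 4, with a slight lean to the higher side as seen with compound 2.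

The estimate for compound 4 is 50000 nM, range 22000 nM to 110000 nM. The expected step is a 1.2-fold higher number from compound 1 to compound 4 (0.08 log units; within the scatter).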

Compound 4, half-maximal inhibitory concentration: 25200 nM
Compound 4: the middle estimate sits 2.0-fold (0.30 log units) above what was measured; the range from low to high includes it.
By their numbers in this assay, from the lowest: compounds 4, 3, 1 and 2 (each within the scatter of the next, the first and the last beyond it).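

In this assay, the move to (2-hydroxy-2-methylbutyl)carbonyl on this oxygen gives the first separation beyond the scatter in the series (a 2.9-fold lower number from compound 2 to compound 4 (0.46 log units; beyond the scatter)), so the group carried here is not entirely silent, as the first three compounds alone left it. That separation is modest and stands only against compound 2, where 2-hydroxy-2-methylbutyl takes the place of oxolan-3-yl on a carbonyl carbon. The other two new steps stay within the scatter (a 1.6-fold lower number from compound 1 to compound 4 (0.22 log units; within the scatter); a 1.6-fold lower number from compound 3 to compound 4 (0.20 log units; within the scatter)), so compound 4 cannot be placed apart from compound 1 or compound 3.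

Nothing available bears on the reason for the step between the two carbonyl-linked compounds. Going by these compounds, it remains open whether the hydroxy group of the 2-hydroxy-2-methylbutyl chain or the chain itself carries the step, and how an amine, a carboxylic acid or a longer unbranched chain on this carbonyl carbon would read in this assay on the same core.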